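A few compounds are considered here, and "the series" means these few. Any claim that something is new, unique, unknown or untested is made for them only; others in the source may bear on it.

Going by the values given here, in a functional assay on SGC-7901 cells (Homo sapiens) for antiproliferative activity, read by MTT assay, with a stated time of 24 h (on this read-out lower numbers stand for stronger inhibition and higher numbers for weaker inhibition), compound 2 `O=C(NNC(=O)c1cccc(NS(=O)(=O)c2cnc(O)nc2O)c1)c1cccc(Cl)c1` gives 7310 nM, the only actual number so far. Compound 1 `Cc1ccccc1C(=O)NNC(=O)c1cccc(NS(=O)(=O)c2cnc(O)nc2O)c1` reads > 20000 nM in this assay, and this is a limit of the assay, not a number.

Next is compound 3 `O=C(NNC(=O)c1cccc(NS(=O)(=O)c2cnc(O)nc2O)c1)c1ccc(F)cc1`, with 4-fluorophenyl in place of 3-chlorophenyl on a carbonyl carbon.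

Among the compounds with values here, one measured step bears on this change, at the same place: an at least 2.7-fold lower number from compound 1 to compound 2 (0.43 log units; beyond the scatter). From the compounds shown here alone, it lies beyond the scatter, and its true size stays open given (the limit of > 20000 nM in this assay, at which 1 of the 2 values shown sits). With a single aryl swap as precedent, no large move is expected in this assay. The expected step is small and towards a higher number, and may stay within the scatter: a 1.5-fold higher number from compound 2 to compound 3 (0.18 log units; within the scatter). For compound 3 the estimated value is 11000 nM, with an expected range of 4000 nM to 28000 nM.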

Compound 3, half-maximal inhibitory concentration: > 20000 nM
Compound 3: no number, only a limit; the forecaster's own chance of this, stated with the estimate: 30%; at least 1.8-fold (0.25 log units) between middle value and limit.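

At this place on the carbonyl carbon, 4-fluorophenyl does not retain the readable result seen with 3-chlorophenyl in this assay: an at least 2.7-fold higher number from compound 2 to compound 3 (0.43 log units; beyond the scatter). A readable number therefore does not hold across the aryl groups shown, with compound 2 alone giving one, while compound 1 and compound 3 both sit at a limit of the assay. The step from compound 1 to compound 3 cannot be read, and the true size of the rise from compound 2 stays open because of the limit: the limit of > 20000 nM in this assay, at which 2 of the 3 values shown sit.

Between compound 2 and compound 3, the halogen and its place on the phenyl ring change together, so the two remain unseparated. Also open, from the compounds shown here alone, is how an amine, a carboxylic acid or a longer chain would read at this place in this assay.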